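The source may report more compounds than this note shows. Statements on the series, on what has been measured and on what is new or still open speak of the compounds shown alone.

Of the compounds shown here, two have been measured in an ADME assay on microsomes from liver (Homo sapiens) for metabolic stability; on this read-out lower numbers stand for a shorter-lived compound and higher numbers for a longer-lived compound. Compound 1 (`CCn1ncc2c(F)cc(-c3ccc(C(CC)(CC)c4nncn4C)c(=O)[nH]3)cc21`) gives 2.67 h, while compound 2 (`Cc1nc(C(c2ccc(-c3ccc4cccc(F)c4c3)[nH]c2=O)C(C)C)[nH]c1C`) gives 0.268 h. Compound 2 therefore holds the lower of the two numbers, and the gap between them lies well beyond the scatter of repeated measurements. Compound 3 (`CC(C)C(c1ccc(-c2ccc3cccc(F)c3c2)[nH]c1=O)N1CCNC1=O`) differs from compound 2 in one place, on a saturated chain carbon bound to an aromatic carbon and a saturated chain carbon: 2-oxoimidazolidin-1-yl in place of 4,5-dimethyl-1H-imidazol-2-yl on a saturated chain carbon bound to an aromatic carbon and a saturated chain carbon. Going by the values given here, no measured pair shows a change of this kind, so its effect in this assay cannot be read directly from the data. Compound 2 differs from compound 1 in more than one place, and the value of compound 1, 2.67 h, offers only a loose sign that higher numbers are reachable. A modest upward move is expected, close to the edge of the scatter, and the estimated change is a 2.2-fold higher number from compound 2 to compound 3 (0.35 log units; beyond the scatter). Compound 3 is expected to give about 0.6 h, with an estimated range of 0.22 h to 1.6 h.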

Compound 3, half-life: 1.03 h
For compound 3 the middle estimate is 1.7-fold (0.23 log units) below the measured one; the range from low to high includes it.
By their numbers in this assay, from the lowest: compound 2; then compound 3; then compound 1.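

The position on a saturated chain carbon bound to an aromatic carbon and a saturated chain carbon now has its first single-change read-out in this assay and is shown to matter there: 2-oxoimidazolidin-1-yl in place of 4,5-dimethyl-1H-imidazol-2-yl gives a 3.8-fold higher number from compound 2 to compound 3 (0.58 log units; beyond the scatter) and so moves the half-life by more than the usual scatter. The change replaces a five-membered aromatic ring with a five-membered non-aromatic ring that carries a double bond outside aromatic rings, while the counts of hydrogen-bond donors and acceptors stay the same, so the step arises without any change in those counts. No measurement at hand accounts for the size or direction of this step.

From the compounds shown here alone, this one pair is all that speaks for the position, so it remains open whether the same replacement would give a similar step on another core, such as the core of compound 1. Going by these compounds, it also remains open how a morpholine, a primary amine or a carboxylic acid at this place would compare with 2-oxoimidazolidin-1-yl.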